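A few compounds are considered here, and "the series" means these few. Any claim that something is new, unique, unknown or untested is made for them only; others in the source may bear on it.

Measured compounds:
compound 1, `COc1nc(N)nc2c1c(-c1ccsc1)cn2[C@@H]1O[C@H](CO)[C@@H](O)[C@H]1O`, > 20000 nM
compound 2, `COc1nc(N)nc2c1c(-c1ccoc1)cn2[C@@H]1O[C@H](CO)[C@@H](O)[C@H]1O`, > 20000 nM
compound 3, `CNc1ncnc2c1c(-c1ccsc1)cn2[C@@H]1O[C@H](CO)[C@@H](O)[C@H]1O`, > 20000 nM

In a functional assay on CCRF-CEM cells (Homo sapiens), read by MTT assay, with a stated time of 72 h (a higher number here means a weaker inhibitor, a lower number a stronger inhibitor), compound 1 gives > 20000 nM, which is a limit of the assay and not a number. Compound 2 likewise gives > 20000 nM in this assay, again a limit. Compound 2 differs from compound 1 by furan-3-yl in place of thiophen-3-yl on an aromatic carbon, and the step that the two limits leave unreadable from compound 1 to compound 2 cannot be read, since both ends rest on a limit.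

Compound 3 carries a different core; the difference between the two cores of compound 1 and compound 3 is not broken down here. In this assay compound 3 gives > 20000 nM, also a limit. All three values therefore sit at the limit of > 20000 nM in this assay, at which 3 of the 3 values shown sit.

Compound 4, `CNc1ncnc2c1c(-c1ccoc1)cn2[C@@H]1O[C@H](CO)[C@@H](O)[C@H]1O`, has not yet been measured in this assay. It differs from compound 3 by furan-3-yl in place of thiophen-3-yl on an aromatic carbon, the same change as that from compound 1 to compound 2. Because that earlier step that the two limits leave unreadable from compound 1 to compound 2 was left unreadable by the two limits, it gives no size to carry over, and because compound 3 sits at the limit of > 20000 nM in this assay, at which 3 of the 3 values shown sit, the expectation for compound 4 is that it will also sit at or beyond the limit. Compound 4 is expected to show about 30000 nM in this assay, within roughly 12000 nM to 100000 nM. The step that the limit leaves unreadable from compound 3 to compound 4 is thus expected to be one that the limit again leaves unreadable.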

Compound 4, half-maximal inhibitory concentration: > 20000 nM
Compound 4: no number, only a limit; the forecaster's own chance of this, stated with the estimate: 85%; the middle value does not contradict the limit.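

In this assay compound 4 gives > 20000 nM, a limit of the assay and not a number. Compound 3 also rests on a limit, and the step from compound 3 to compound 4 cannot be read. The compounds shown share one ceiling: the limit of > 20000 nM in this assay, at which 4 of the 4 values shown sit.

Going by these compounds, what stays open is how far each of the four compounds lies beyond that limit, and whether furan-3-yl and thiophen-3-yl differ at all in this assay.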